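The source may hold more compounds than are shown below. What is called first, only, known or untested is meant among the compounds shown, and "the series" means these compounds.

In a functional assay on HeLa cells (Homo sapiens) for cytotoxicity, read by cell counting, with a stated time of 4 days (on this read-out lower numbers stand for stronger inhibition and higher numbers for weaker inhibition), three compounds built on one shared core have been measured. Compound 1 `C=C(Br)C(=O)Nc1ccc(/C=C2\SC(=O)N(Cc3cccc(F)c3)C2=O)cc1` gives 5900 nM. Compound 2 `CC(C)(C)c1ccc(CN2C(=O)S/C(=C\c3cccc(N)c3)C2=O)cc1` gives 145000 nM, and compound 3 `C=C(Br)C(=O)Nc1cccc(/C=C2\SC(=O)N(Cc3ccc(F)cc3)C2=O)c1` gives 800 nM. On these numbers compound 1 stands second highest of the three: compound 3 shows a lower number, a gap beyond the usual scatter of repeated measurements, while compound 2 shows a higher number, also beyond that scatter. Going by the values given here, no two of the measured compounds differ in only one place, so no single structural step has yet been measured directly.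

Compound 4 `C=C(Br)C(=O)Nc1ccc(/C=C2\SC(=O)N(C)C2=O)cc1` has not been tested in this assay. It differs from compound 1 in one place: hydrogen in place of 3-fluorophenyl on a saturated chain carbon bound to an amide-type nitrogen in a ring. The same change, cut one bond further out, reads 3-fluorobenzyl to methyl. Among the compounds with values here, the measured compounds offer no step of this kind to lean on, so the expectation rests on the change alone. The number is expected to rise, a step of about a 2.5-fold higher number from compound 1 to compound 4 (0.41 log units; beyond the scatter), somewhat beyond the scatter. Compound 4 is therefore expected to give around 15000 nM in this assay, with a likely range from 4000 nM to 60000 nM.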

Compound 4, half-maximal inhibitory concentration: 870 nM
Beside the measured number, compound 4's estimate is 17-fold (1.24 log units) above it, outside the stated range (below it).
By their numbers in this assay, from the lowest: compounds 3 and 4 (each within the scatter of the next); then compound 1; then compound 2.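

In this assay, cutting 3-fluorobenzyl back to methyl gives a 6.8-fold lower number from compound 1 to compound 4 (0.83 log units; beyond the scatter), and on this read-out a lower number means stronger inhibition. Going by these compounds alone, this is the first direct look at this position, on a saturated chain carbon bound to an amide-type nitrogen in a ring, and it shows that the 3-fluorophenyl group is not needed for activity against these cells. In this one pair, removing the group strengthens the effect instead of weakening it, though a single step cannot show whether the same would hold on a different core.

Still open, from the compounds shown here alone, is how a longer chain, such as a propyl group, or a chain ending in an amine would compare with methyl at this position. Nothing measured here explains why the number falls.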